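Methyl in place of chloro: the step from compound 1

The source may hold more compounds than are shown below. What is called first, only, known or untested is meant among the compounds shown, and "the series" means these compounds.

Compound 1 `Fc1cccc(-c2nc(Nc3ccccc3Cl)c3cc(F)ccc3n2)c1` is tested in a functional assay on U2OS cells (Homo sapiens) for cytotoxicity, read by MTT assay, with a stated time of 48 h; a lower number here means a stronger inhibitor, a higher number a weaker inhibitor. In this assay compound 1 reaches only the assay limit > 50000 nM. Compound 2 `Oc1ccccc1Nc1nc(-c2cccc(F)c2)nc2ccc(F)cc12` gives 41400 nM in this assay. Compound 3 `Cc1cccc(Nc2nc(-c3cccc(F)c3)nc3ccc(F)cc23)c1` also stops at the assay limit > 50000 nM in this assay. Among the measured steps, an at least 1.2-fold lower number from compound 1 to compound 2 (0.08 log units; that floor lies within the scatter) and an at least 1.2-fold higher number from compound 2 to compound 3 (0.08 log units; that floor lies within the scatter) are floored, while a step that the two limits leave unreadable from compound 1 to compound 3. Two of the three values sit at the limit of > 50000 nM in this assay, at which 2 of the 3 values shown sit. Compound 4 `Cc1ccccc1Nc1nc(-c2cccc(F)c2)nc2ccc(F)cc12` differs from compound 1 by methyl in place of chloro on an aromatic carbon. Among the compounds with values here, no measured step exchanges chloro for methyl; the nearest neighbour is compound 3, which carries a 3-methylphenyl and stays at the limit. Compound 4 is therefore expected to show a number no higher from compound 1 to compound 4 (the limit leaves the size open), nothing readable beyond the scatter. The estimate for compound 4 is 50000 nM, between 30000 nM and 150000 nM.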

Compound 4, half-maximal inhibitory concentration: > 50000 nM
Compound 4: only a limit was reported; the forecaster's own chance of this, stated with the estimate: 70%; the middle value sits exactly at the limit.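

Methyl at this place, on an aromatic carbon ortho to a large group, leaves compound 4 at the assay limit in this assay, so neither chloro nor methyl there gives a number that can be read: the limit of > 50000 nM in this assay, at which 3 of the 4 values shown sit. The steps to compound 4 from compound 1 and from compound 3 cannot be read, since both ends are limits. Within the data shown here, the one readable step, methyl in place of hydroxy, is an at least 1.2-fold higher number from compound 2 to compound 4 (0.08 log units; that floor lies within the scatter).

Going by these compounds, whether an amine or a carboxylic acid at this place would give a value clearly under the limit stays open.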